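A few compounds are considered here, and "the series" means these few. Any claim that something is new, unique, unknown or untested is made for them only; others in the source may bear on it.

Measured so far:
- compound 1 `COc1cc(/C=C/C(=O)/C=C/c2cc(OC)c(OC)c(OC)c2)ccc1OCc1cn(CCOc2cc(=O)oc3ccccc23)nn1`: 99%
- compound 2 `COc1cc(/C=C/C(=O)/C=C/c2cccs2)ccc1OCc1cn(CCCCCOc2cc(=O)oc3ccccc23)nn1`: 34%
- compound 3 `COc1cccc(/C=C/C(=O)/C=C/c2ccc(OCc3cn(CCCCCOc4cc(=O)oc5ccccc45)nn3)c(OC)c2)c1`: 37%

In a functional assay on THP-1 cells (Homo sapiens) for inhibition, read by sulforhodamine B assay, with a stated time of 48 h, tested at 50 uM (on this read-out lower numbers stand for less inhibition of growth and higher numbers for more inhibition of growth at the one concentration tested), compound 1 stands highest of the three numbers, with compound 3 nearest and compound 2 furthest, both gaps beyond the scatter. Compound 4 `COc1cc(/C=C/C(=O)/C=C/c2ccco2)ccc1OCc1cn(CCOc2cc(=O)oc3ccccc23)nn1` is not yet measured. It differs from compound 1 in one place: furan-2-yl in place of 3,4,5-trimethoxyphenyl on a double-bonded chain carbon bound to a double-bonded chain carbon. For the measured compounds named here, no measured step matches this exchange directly. Going by the values given here, the only single-place step, a number 3 percentage points higher from compound 2 to compound 3 (within the scatter), lies within the scatter and swaps one five-membered aromatic ring bearing one hetero atom for a methoxyphenyl group, so it gives no size for moving from 3,4,5-trimethoxyphenyl to furan-2-yl. Compounds 2 and 3 differ from compound 1 in more than this one place, so their lower numbers cannot be attributed to the aromatic group alone. Given that compound 1 sits well apart from both, a drop is expected in this assay, of uncertain size; the step of a number 39 percentage points lower from compound 1 to compound 4 (beyond the scatter) is the estimate. For compound 4 the expected value is 60%, within 30% to 95%.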

Compound 4, percent growth inhibition at one concentration: 78%
For compound 4 the middle estimate is 18 percentage points below the measured one, and the stated range covers the measured number.
By their numbers in this assay, from the lowest: compounds 2 and 3 (each within the scatter of the next); then compound 4; then compound 1.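

In this assay, the exchange of 3,4,5-trimethoxyphenyl for furan-2-yl on a double-bonded chain carbon bound to a double-bonded chain carbon now has a measured size: a number 21 percentage points lower from compound 1 to compound 4 (beyond the scatter), beyond the scatter but modest, with the smaller group still leaving compound 4 at 78%. The earlier step at this place, a number 3 percentage points higher from compound 2 to compound 3 (within the scatter), stayed within the scatter, so this is the first exchange here shown to move the number beyond it. Nothing at hand accounts for the size of this step.

Open is how much of the distance from compound 1 to compound 2 and compound 3 belongs to their longer chain, as no pair shown differs in that place alone. Also open, as far as these compounds go, is what an unsubstituted phenyl, a pyridin-3-yl or a phenyl bearing a carboxylic acid would give at this place.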